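The compounds below may be only part of what the source reports. "The series", "measured", "known", "first", "only" and "open" are said of these compounds alone.

Working notes on the series

All three measured compounds carry the core of compound 1 `CCC1(Cc2ccccc2)OS(=O)(=O)C=C1OCC(=O)OC`. In an ADME assay on HEL cells (Homo sapiens) for cytotoxicity, with a stated time of 3 days (a lower number here means that less compound is tolerated, a higher number that more compound is tolerated), compound 1 gives only a limit, > 400000 nM. Compound 2 `CCC1(Cc2ccccc2)OS(=O)(=O)C=C1OC` in this assay likewise gives only a limit, > 400000 nM. Compound 3 `CCC1(Cc2ccccc2)OS(=O)(=O)C=C1OCc1ccc(OC)cc1` in this assay also stops at a limit, >= 200000 nM. Compound 3 therefore stands nowhere readable among the numbers shown: it is a limit, and the two other values are limits as well. The steps between the measured compounds are accordingly unreadable: a step that the two limits leave unreadable from compound 1 to compound 2, a step that the two limits leave unreadable from compound 1 to compound 3 and a step that the two limits leave unreadable from compound 2 to compound 3 all sit between limits. Within the data shown here, the only evidence at hand is the limit of > 400000 nM in this assay, at which 2 of the 3 values shown sit, and (the limit of >= 200000 nM in this assay, at which 1 of the 3 values shown sits).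

Compound 4 `CCC1(Cc2ccccc2)OS(=O)(=O)C=C1OCc1ccccc1` is the next member. It differs from compound 3 by hydrogen in place of methoxy on an aromatic carbon. Among the measured compounds shown here, the step that bears on this change is the one from compound 2 to compound 3, which introduced the 4-methoxyphenyl and whose size the two limits left unreadable. No readable step exists in the series, so no direction of change in this assay can be expected beyond a limit. Compound 4 is estimated at 300000 nM, within 100000 nM to 1000000 nM. The step this estimate means is a step that the limit leaves unreadable from compound 3 to compound 4, expected to be nothing beyond the scatter, most likely another limit.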

Compound 4, minimum cytotoxic concentration: >= 50000 nM
Compound 4: only a limit was reported (the forecaster's own chance of this, stated with the estimate: 85%); the middle value does not contradict the limit.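

In this assay compound 4 gives only a limit, >= 50000 nM. Its steps to compound 1, compound 2 and compound 3 all lie between limits, and none of them can be read. The compounds shown leave open whether exchanging the group on the shared core changes the minimum cytotoxic concentration in this assay at all, and in which direction.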